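This account rests on a few compounds, and the source may have more. Where it says the series, first, only, none or still open, it means among the compounds named here.

Measured compounds:
- Compound 1, `CC(=O)OC/C(=C\c1ccc(Cl)cc1Cl)C(=O)c1ccccc1`: in a functional assay on MCF7 cells (Homo sapiens) for inhibition, read by XTT assay, with a stated time of 48 h (a lower number here means a stronger inhibitor, a higher number a weaker inhibitor), compound 1 gives 8700 nM.
- Compound 2, `COc1ccc(C(=O)/C(=C/C2CCCCC2)COC(C)=O)cc1`: in this assay compound 2 gives 24000 nM.
- Compound 3, `COc1ccc(C(=O)/C(=C/C2CCCCC2)COC(=O)c2ccccc2)cc1`: in this assay compound 3 gives 13700 nM.

Compound 3 holds the second highest of these three numbers, with compound 1 nearest and compound 2 furthest, and both of those gaps lie within the usual scatter of this assay. Among the compounds with values here, the only single-point step among the measured compounds is a 1.8-fold lower number from compound 2 to compound 3 (0.24 log units; within the scatter), which also stays within the scatter.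

Compound 4, `COc1ccc(C(=O)/C(=C/c2ccccc2Cl)COC(=O)c2ccccc2)cc1`, differs from compound 3 in one place: 2-chlorophenyl in place of cyclohexyl on a double-bonded chain carbon bound to a double-bonded chain carbon. Within the data shown here, no measured step touches this position, so nothing here tells directly how this swap acts. The step from compound 2 to compound 3 concerns a different part of the molecule and does not bear on it. Compound 1 carries an aromatic ring at the same chain carbon, but it differs from compound 3 in several places at once, so its value and that of compound 3 can only be set side by side, and the two lie within the scatter of each other.

On that basis compound 4 is expected to give 10000 nM in this assay, with a range from 3500 nM to 30000 nM. The expected step is a 1.4-fold lower number from compound 3 to compound 4 (0.14 log units; within the scatter), not beyond the scatter.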

Compound 4, half-maximal inhibitory concentration: 9000 nM
Estimate against measurement, compound 4: 1.1-fold (0.05 log units) above, within the range that was stated.
By their numbers in this assay, from the lowest: compounds 1, 4, 3 and 2 (each within the scatter of the next, the first and the last beyond it).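

Within the data shown here, this is the first measured change at this position, on a double-bonded chain carbon bound to a double-bonded chain carbon, and in this assay it amounts to a 1.5-fold lower number from compound 3 to compound 4 (0.18 log units; within the scatter) and stays within the usual scatter of repeated measurements. A non-aromatic ring of carbon only can therefore give way to an aromatic ring carrying a chlorine, with one more heavy atom, and the two compounds still cannot be told apart in this assay, although this rests on a single pair with everything else held as in compound 3. Nothing available explains why the two groups read alike, and no supporting measurement bears on the point.

From the compounds shown here alone, what remains open is whether a ring matters at this position at all, since an open chain such as a longer alkyl chain, or a group such as an amine or a carboxylic acid, could give a clearly different number or much the same one. Going by these compounds, it is also open whether the chlorine contributes anything, which a plain phenyl group at this position would help to show.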